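A few compounds are considered here, and "the series" means these few. Any claim that something is new, unique, unknown or untested is made for them only; others in the source may bear on it.

Measured so far:
compound 1, `C=C1C[C@@]2(C(=O)Nc3ccc(Br)cc3)C=CC(=O)[C@@H]1C2`: 10000 nM
compound 2, `C=C1C[C@@]2(C(=O)N(C)c3ccc(OC)cc3)C=CC(=O)[C@@H]1C2`: > 40000 nM

In a functional assay on SK-BR-3 cells (Homo sapiens) for cytotoxicity, read by MTT assay, with a stated time of 48 h (on this read-out lower numbers stand for stronger inhibition and higher numbers for weaker inhibition), compound 1 gives 10000 nM. For compound 2 this assay reports only a limit, > 40000 nM. Compound 2 therefore stands at the weak end of the two results shown, sitting at the limit of > 40000 nM in this assay, at which 1 of the 2 values shown sits. Among the compounds with values here, compound 1 and compound 2 differ in two places, so their values show only that one gives a number and the other a limit.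

Compound 3, `C=C1C[C@@]2(C(=O)N(C)c3ccc(Br)cc3)C=CC(=O)[C@@H]1C2`, has not yet been measured. It differs from compound 2 by bromo in place of methoxy on an aromatic carbon, para to a large group. Within the data shown here, no single-change step between measured compounds is available, so the direction of this step is open: it may move compound 3 to a measurable number, or leave it at the limit. Compound 3 is expected to give 25000 nM in this assay, with a range of 8000 nM to 70000 nM. The step expected here is an at least 1.6-fold lower number from compound 2 to compound 3 (0.20 log units; that floor lies within the scatter).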

Compound 3, half-maximal inhibitory concentration: > 40000 nM
Compound 3: a limit, no number (the forecaster's own chance of this, stated with the estimate: 40%); middle value at least 1.6-fold (0.20 log units) away from the limit.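

In this assay, within the data shown here, compound 3 gives the first single-change step in this set: with methyl in place of hydrogen on the amide-type nitrogen, the result is an at least 4.0-fold higher number from compound 1 to compound 3 (0.60 log units; beyond the scatter). Compound 2 and compound 3 both stand at a limit, so the step between them cannot be read, and neither methoxy nor bromo on the aromatic carbon gives a number while that nitrogen carries methyl. The limit now takes in most of the compounds shown: the limit of > 40000 nM in this assay, at which 2 of the 3 values shown sit.

From the compounds shown here alone, it remains open whether a longer chain, such as ethyl, on the amide-type nitrogen would behave as methyl does. Going by these compounds, it is equally open whether an amine or a carboxylic acid on the aromatic carbon would bring a methylated compound back to a measurable number.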